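Replacing a Halogen with a Bulky Alkyl Group on the Chalcone

The source may hold more compounds than are shown below. What is called first, only, known or untested is meant among the compounds shown, and "the series" means these compounds.

Compound 3 `O=C(COc1ccc(C(=O)/C=C/c2ccccc2Br)cc1)N[C@H]1CCOC1=O` gives 15300 nM in a functional assay on MCF7 cells (Homo sapiens) for antiproliferative activity, read by MTT assay, with a stated time of 72 h; on this read-out lower numbers stand for stronger inhibition and higher numbers for weaker inhibition. Compound 1 `O=C(COc1ccc(C(=O)/C=C/c2ccccc2Cl)cc1)N[C@H]1CCOC1=O` gives 17400 nM, so the two sit together, since a 1.1-fold lower number from compound 1 to compound 3 (0.06 log units; within the scatter). Compound 2 `CCOc1ccccc1OCCSC(=S)N[C@H]1CCOC1=O` reaches only a limit of the assay, > 64000 nM. Compound 4 `CC(C)(C)c1ccc(/C=C/C(=O)c2ccc(OCC(=O)N[C@H]3CCOC3=O)cc2)cc1` differs from compound 3 by 4-(tert-butyl)phenyl in place of 2-bromophenyl on a double-bonded chain carbon bound to a double-bonded chain carbon. For the measured compounds named here, no measured step swaps a halogen for an alkyl group; the only step available, a halogen swap, stayed within the scatter, and the limit of > 64000 nM in this assay, at which 1 of the 3 values shown sits, belongs to a structure too far removed to guide this change. A step no larger than the scatter is therefore expected, in either direction. For compound 4 the estimate is 12000 nM, between 4000 nM and 40000 nM, meaning an expected 1.3-fold lower number from compound 3 to compound 4 (0.11 log units; within the scatter).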

Compound 4, half-maximal inhibitory concentration: 16400 nM
Estimate against measurement, compound 4: 1.4-fold (0.14 log units) below; measured number inside the range.
By their numbers in this assay, from the lowest: compounds 3, 4 and 1 (each within the scatter of the next). At a limit, above all of these: compound 2.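

Exchanging the whole aryl group on this double-bonded chain carbon, and not only its halogen, leaves the number in this assay in place (a 1.1-fold higher number from compound 3 to compound 4 (0.03 log units; within the scatter)). The comparison with the chlorine analogue reads the same (a 1.1-fold lower number from compound 1 to compound 4 (0.03 log units; within the scatter)), so 4-(tert-butyl)phenyl, which carries no halogen, matches both halogenated rings here. For the compounds shown here, nothing measured so far accounts for this lack of change.

Going by these compounds, whether an aryl group bearing an amine or a carboxylic acid would stay level with these compounds remains open. So does whether any replacement here can move the number beyond the scatter.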